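Cyclopentylcarbamoyl in Place of Propylcarbonyl on Compound 1

The compounds below may be only part of what the source reports. "The series", "measured", "known", "first", "only" and "open" are said of these compounds alone.

The measured compounds:
compound 1, `CCCC(=O)Nc1ccc(S(=O)(=O)Oc2ccccc2C(C)C)cc1`, in a functional assay on MCF7 cells (Homo sapiens) for antiproliferative activity, read by sulforhodamine B assay, with a stated time of 48 h; on this read-out lower numbers stand for stronger inhibition and higher numbers for weaker inhibition: 6600 nM
compound 2, `CCCC(=O)Nc1ccc(S(=O)(=O)Oc2ccccc2I)cc1`, in this assay: 9700 nM
compound 3, `O=C(CCCCl)Nc1ccc(S(=O)(=O)Oc2ccccc2I)cc1`, in this assay: 6300 nM

Compound 1 sits among three numbers that all lie within the scatter of one another: its closest neighbour is compound 3, and the widest gap is to compound 2. The two steps among these compounds, a 1.5-fold higher number from compound 1 to compound 2 (0.17 log units; within the scatter) and a 1.5-fold lower number from compound 2 to compound 3 (0.19 log units; within the scatter), both stay within the scatter, and neither touches the carbonyl carbon that distinguishes compound 4, `CC(C)c1ccccc1OS(=O)(=O)c1ccc(NC(=O)NC2CCCC2)cc1`, from compound 1. The change is cyclopentylamino in place of propyl on a carbonyl carbon; the same difference, cut one bond further out, reads propylcarbonyl to cyclopentylcarbamoyl. For the measured compounds named here, no measured step alters this part of the molecule, so the expectation rests only on the narrow spread of the three numbers seen so far. On that basis compound 4 is expected to give 6000 nM, with a range from 2000 nM to 18000 nM. The expected step is a 1.1-fold lower number from compound 1 to compound 4 (0.04 log units; within the scatter), that is, none beyond the scatter.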

Compound 4, half-maximal inhibitory concentration: 6200 nM
For compound 4 the middle estimate is 1.0-fold (0.01 log units) below the measured one; the measured number falls inside the stated range.
By their numbers in this assay, from the lowest: compounds 4, 3, 1 and 2 (each within the scatter of the next).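

In this assay, cyclopentylamino in place of propyl on the carbonyl carbon gives a 1.1-fold lower number from compound 1 to compound 4 (0.03 log units; within the scatter). This is the first change at this position among the compounds shown, and it shows that a larger group, bringing a five-membered non-aromatic ring of carbon only and a hydrogen-bond donor, leaves the number within the scatter of that of compound 1. No supporting data bear on why this change makes so little difference.

Going by these compounds, it remains open whether a phenyl ring, a longer chain or a carboxylic acid on the same carbonyl carbon would take the number beyond the scatter. On these data alone, it is also open whether cyclopentylamino would behave in the same way on compound 2, which carries iodo in place of isopropyl.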